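A dimethylphenyl swap among compounds measured only as limits

A few compounds are considered here, and "the series" means these few. Any claim that something is new, unique, unknown or untested is made for them only; others in the source may bear on it.

Measured so far in a functional assay on HepG2 cells (Homo sapiens) for antiproliferative activity, read by spectrophotometry, with a stated time of 2 days; on this read-out lower numbers stand for stronger inhibition of growth and higher numbers for weaker inhibition of growth:
- compound 1 (`Cc1ccc(Nc2ncc(C(F)(F)F)c(N3Cc4cccc(N(C)S(C)(=O)=O)c4C3)n2)cc1C`) gives > 30000 nM as a limit
- compound 2 (`CN(c1cccc2c1CN(c1nc(Nc3ccc(C(F)(F)F)cc3)ncc1C(F)(F)F)C2)S(C)(=O)=O`) gives > 30000 nM as a limit
- compound 3 (`Cc1cc(C)cc(Nc2ncc(C(F)(F)F)c(N3Cc4cccc(N(C)S(C)(=O)=O)c4C3)n2)c1`) gives > 30000 nM as a limit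

Compound 3 therefore has a limit and not a number, and the two other compounds end the same way. The whole set shows the limit of > 30000 nM in this assay, at which 3 of the 3 values shown sit, and no measured number.

Compound 4 (`Cc1ccc(Nc2ncc(C(F)(F)F)c(N3Cc4cccc(N(C)S(C)(=O)=O)c4C3)n2)c(C)c1`) has not yet been measured. Its difference from compound 3 reads 2,4-dimethylphenyl in place of 3,5-dimethylphenyl on a nitrogen on an aromatic ring in full. In short, it is 2,4-dimethylphenyl in place of 3,5-dimethylphenyl on a nitrogen on an aromatic ring, the two having the same atoms, joined differently.

Three measured steps exchange the group at that same place. They are a step that the two limits leave unreadable from compound 1 to compound 3 and a step that the two limits leave unreadable from compound 2 to compound 3 together with a step that the two limits leave unreadable from compound 1 to compound 2 in the same series. None of them has a readable size, so none of them gives a direction. Going by the values given here, no step of known size or direction is therefore expected in this assay for this change, and compound 4 will most likely be reported only as a limit too.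

The estimated change is a number no higher from compound 3 to compound 4 (the limit leaves the size open) in this reading. For compound 4 the expected value is 30000 nM with an estimated range from 15000 nM to 60000 nM in all.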

Compound 4, concentration for 50% growth inhibition: 19100 nM
Estimate against measurement, compound 4: 1.6-fold (0.20 log units) above; the measured number falls inside the stated range.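

Going by these compounds alone, changing the 3,5-dimethylphenyl group to the 2,4-dimethylphenyl group, on a nitrogen on an aromatic ring, gives the only measured number in the set: in this assay compound 4 gives 19100 nM. This shows that two isomeric groups with the same atoms can differ in outcome at this place, with an at least 1.5-fold lower number from compound 3 to compound 4 (0.19 log units; that floor lies within the scatter), while the comparisons with the other two compounds read an at least 1.5-fold lower number from compound 2 to compound 4 (0.19 log units; that floor lies within the scatter) and an at least 1.5-fold lower number from compound 1 to compound 4 (0.19 log units; that floor lies within the scatter). Each of these three steps is only a floor, and because that floor lies within the scatter, a real gain from the 2,4-dimethylphenyl group is possible but not established, as the other three compounds give only a limit and not a number: the limit of > 30000 nM in this assay, at which 3 of the 4 values shown sit.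

Going by these compounds, the true values of compound 1, compound 2 and compound 3 stay unknown, so the steps among them cannot be read and the full size of each step to compound 4 remains open. Also open, on these data alone, is what a methoxyphenyl or a pyridyl group would give at this same place, and whether any group here can bring growth inhibition far stronger than that of compound 4.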